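Swapping the cyclopropylcarbamoyl group for a chlorine

The source may hold more compounds than are shown below. What is called first, only, known or untested is meant among the compounds shown, and "the series" means these compounds.

Compound 1 `Cc1cc(CCC#N)cc(C)c1Oc1cc(Nc2ccc(C#N)cc2)c(N)cc1C(=O)NC1CC1` is the reference point of this short series. In an ADME assay on TZM cells (Homo sapiens) for cytotoxicity, with a stated time of 1 days (a higher number here means that more compound is tolerated, a lower number that less compound is tolerated), compound 1 gives 121000 nM, the highest of the two numbers recorded; its nearest neighbour is compound 2 `CNC(=O)OCc1cc(N)c(Nc2ccc(C#N)cc2)cc1Oc1c(C)cc(CCC#N)cc1C`, which in this assay gives 46800 nM. Among the compounds with values here, the one measured step that changes the same position, a 2.6-fold lower number from compound 1 to compound 2 (0.41 log units; beyond the scatter), therefore shows that replacing the cyclopropylcarbamoyl group with a different substituent can move the number modestly downward, though only a single example exists and nothing is known about a chlorine at that site.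

Compound 3 `Cc1cc(CCC#N)cc(C)c1Oc1cc(Nc2ccc(C#N)cc2)c(N)cc1Cl` differs from compound 1 as follows: chloro in place of cyclopropylcarbamoyl on an aromatic carbon. Within the data shown here, since the only relevant precedent is the modest lowering seen in a 2.6-fold lower number from compound 1 to compound 2 (0.41 log units; beyond the scatter), a similar or smaller downward movement is expected, and a result within the scatter of compound 1 cannot be excluded. On that basis compound 3 is expected to reach about 70000 nM in this assay, with a plausible range from 30000 nM to 150000 nM, corresponding to an estimated step of a 1.7-fold lower number from compound 1 to compound 3 (0.24 log units; within the scatter).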

Compound 3, half-maximal cytotoxic concentration: 10400 nM
Compound 3: middle estimate off by 6.7-fold (0.83 log units), on the high side, and the stated range ends above it.
By their numbers in this assay, from the lowest: compound 3; then compound 2; then compound 1.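

In this assay the change from cyclopropylcarbamoyl to chloro gives a 12-fold lower number from compound 1 to compound 3 (1.07 log units; beyond the scatter) at this aromatic carbon, so the number here can move much further than a 2.6-fold lower number from compound 1 to compound 2 (0.41 log units; beyond the scatter) had shown. The step of a 4.5-fold lower number from compound 2 to compound 3 (0.65 log units; beyond the scatter) places chloro under ((methylcarbamoyl)oxy)methyl as well, so the three groups at this position now fall in a single order, with chloro lowest and cyclopropylcarbamoyl highest. Chloro has 1 heavy atom and no hydrogen-bond donor or acceptor, where cyclopropylcarbamoyl has 6 heavy atoms and one of each, but no measurement offered here accounts for the lower number.

The compounds shown leave open whether the number follows the chlorine itself or the loss of the cyclopropylcarbamoyl group, and a fluorine, a methyl or a plain primary amide at this aromatic carbon would help to separate those two readings. They also leave open whether the same order would hold on a different core, as all three compounds share one.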